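From Ethyl to Propyl: One More Chain Step

A few compounds are considered here, and "the series" means these few. Any claim that something is new, unique, unknown or untested is made for them only; others in the source may bear on it.

In a functional assay on PC-3 cells (Homo sapiens) for cytotoxicity, read by WST assay, with a stated time of 3 days (on this read-out lower numbers stand for stronger inhibition and higher numbers for weaker inhibition), compound 1 (`Cn1ccnc1/C=C/C(=O)/C=C/c1coc2ccccc2c1=O`) gives 2800 nM and compound 2 (`CCn1ccnc1/C=C/C(=O)/C=C/c1coc2ccccc2c1=O`) gives 1800 nM. Going by the values given here, these are the only two numbers available, and they cannot be told apart: the step, a 1.6-fold lower number from compound 1 to compound 2 (0.19 log units; within the scatter), does not separate them. Compound 2 therefore stands level with compound 1.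

The next compound, compound 3 (`CCCn1ccnc1/C=C/C(=O)/C=C/c1coc2ccccc2c1=O`), differs from compound 2 in one place: methyl in place of hydrogen on a saturated chain carbon, two bonds along the chain from an aromatic nitrogen. This is methyl in place of hydrogen on a saturated chain carbon, two bonds along the chain from an aromatic nitrogen, so that ethyl becomes propyl.

Among the compounds with values here, only one measured step bears on this change, the one that turned methyl into ethyl on the same chain, a 1.6-fold lower number from compound 1 to compound 2 (0.19 log units; within the scatter). It is a single step, so it establishes no trend along the chain. No shift beyond the scatter is therefore expected in this assay, and no direction is favoured with any confidence. The expected step, a 1.1-fold lower number from compound 2 to compound 3 (0.05 log units; within the scatter), is an estimate that stays within the scatter. For compound 3 the estimated value is 1600 nM, with an expected range from 700 nM to 3500 nM.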

Compound 3, half-maximal inhibitory concentration: 2400 nM
The estimate for compound 3 lay 1.5-fold (0.18 log units) below the measured number, within the range that was stated.
By their numbers in this assay, from the lowest: compounds 2, 3 and 1 (each within the scatter of the next).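

In this assay, going by these compounds alone, the second lengthening of the chain, from ethyl to propyl, also stays inside the scatter (a 1.3-fold higher number from compound 2 to compound 3 (0.12 log units; within the scatter)), and its direction is not the one printed for the change from methyl to ethyl (a 1.6-fold lower number from compound 1 to compound 2 (0.19 log units; within the scatter)), though neither step can be told from noise. The end-to-end change, from methyl straight to propyl, is no more separable (a 1.2-fold lower number from compound 1 to compound 3 (0.07 log units; within the scatter)), so methyl, ethyl and propyl cannot be told apart in this read-out, and no trend with chain length appears among compounds 1, 2 and 3. Nothing measured alongside these cytotoxicity numbers offers any explanation for this result.

The compounds shown stop at propyl, so it remains open whether a longer chain such as butyl or hexyl, or a branched one such as isopropyl, would move the number beyond the scatter. It is equally open whether a chain ending in an amine or a carboxylic acid would do so, since every group shown here is a plain saturated chain on the same shared core.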